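Hydroxy groups on the aryl end of a long chain

The compounds below may be only part of what the source reports. "The series", "measured", "known", "first", "only" and "open" are said of these compounds alone.

- compound 1 `C=C/C=C\[C@H](C)[C@H](OC(N)=O)[C@@H](C)[C@H](O)[C@@H](C)C/C(C)=C\[C@H](C)[C@@H](O)[C@@H](C)/C=C\CCc1ccc(C)c(O)c1`: 4000 nM
- compound 2 `C=C/C=C\[C@H](C)[C@H](OC(N)=O)[C@@H](C)[C@H](O)[C@@H](C)C/C(C)=C\[C@H](C)[C@@H](O)[C@@H](C)/C=C\CCc1ccccc1`: 560 nM
- compound 3 `C=C/C=C\[C@H](C)[C@H](OC(N)=O)[C@@H](C)[C@H](O)[C@@H](C)C/C(C)=C\[C@H](C)[C@@H](O)[C@@H](C)/C=C\CCc1cccc(OC)c1`: 500 nM

All three compounds were tested in a functional assay on MCF7 cells (Homo sapiens) for cytotoxicity; on this read-out higher numbers stand for weaker inhibition and lower numbers for stronger inhibition. Compound 3 sits at the low end of these numbers, which means stronger inhibition. Its closest neighbour is no real distance away: a 1.1-fold lower number from compound 2 to compound 3 (0.05 log units; within the scatter). Its furthest neighbour lies well off: an 8.0-fold lower number from compound 1 to compound 3 (0.90 log units; beyond the scatter).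

The next compound is compound 4 `C=C/C=C\[C@H](C)[C@H](OC(N)=O)[C@@H](C)[C@H](O)[C@@H](C)C/C(C)=C\[C@H](C)[C@@H](O)[C@@H](C)/C=C\CCc1cc(O)cc(O)c1`. It puts 3,5-dihydroxyphenyl in place of 3-methoxyphenyl on a saturated chain carbon, two bonds along the chain from a double-bonded chain carbon.

Among the compounds with values here, compound 1 is the only measured compound with a hydroxy group on its aromatic ring. Replacing its 3-hydroxy-4-methylphenyl with plain phenyl gave a 7.1-fold lower number from compound 1 to compound 2 (0.85 log units; beyond the scatter). Adding methoxy to that phenyl then made no difference beyond the scatter: a 1.1-fold lower number from compound 2 to compound 3 (0.05 log units; within the scatter). Within the data shown here, compound 1 also carries a methyl group, so the data cannot separate the hydroxy group from the methyl group, and no measured compound has two hydroxy groups.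

Among the measured compounds shown here, the single hydroxy example still points towards a higher number, so a step back up of modest size is expected. The estimated step is a 5.0-fold higher number from compound 3 to compound 4 (0.70 log units; beyond the scatter). Compound 4 is expected at 2500 nM, with an estimated range of 700 nM to 8000 nM.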

Compound 4, half-maximal inhibitory concentration: > 1000 nM
Compound 4 was reported as a limit (the forecaster's own chance of this, stated with the estimate: 10%); the middle value does not contradict the limit.
By their numbers in this assay, from the lowest: compounds 3 and 2 (each within the scatter of the next); then compound 1.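

Compound 4 is the only compound here reported as a limit, not as a number: the limit of > 1000 nM in this assay, at which 1 of the 4 values shown sits.

Its steps therefore give only floors, an at least 2.0-fold higher number from compound 3 to compound 4 (0.30 log units; that floor lies within the scatter) and an at least 1.7-fold higher number from compound 2 to compound 4 (0.25 log units; that floor lies within the scatter), and the true distance could be larger; the step to compound 1 cannot be read. What is new is that compound 4 carries hydroxy groups on the ring without the methyl group of compound 1, so a ring without that methyl group can also give a value that is only known as a limit, although these floors alone do not separate compound 4 from compound 2 or compound 3.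

Going by these compounds, whether the second hydroxy group changes anything compared with one, and how much of the value of compound 1 belongs to its methyl group, remain open without a firm number for compound 4. Also open, on these data alone, is how the 2-phenylethyl end would respond to an amine or a carboxylic acid on the ring, or to a longer chain between the ring and the double bond.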